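A few compounds are considered here, and "the series" means these few. Any claim that something is new, unique, unknown or untested is made for them only; others in the source may bear on it.

Measured compounds in a functional assay on MCF7 cells (Homo sapiens) for cytotoxicity, read by MTT assay, with a stated time of 48 h; on this read-out lower numbers stand for stronger inhibition and higher numbers for weaker inhibition:
- compound 1 `COc1ccc(/C=N/n2c(SCc3ccccc3Cl)nnc2-c2cc(OC)c(OC)c(OC)c2)c(OC)c1` gives 63700 nM
- compound 2 `COc1ccc(/C=N/n2c(SCc3ccccc3)nnc2-c2cc(OC)c(OC)c(OC)c2)c(OC)c1` gives 153000 nM

Compound 2 stands highest of the two numbers recorded; its nearest neighbour is compound 1, and the step of a 2.4-fold higher number from compound 1 to compound 2 (0.38 log units; beyond the scatter) separates them, a hydrogen in place of chloro on an aromatic carbon of the benzylsulfanyl group.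

Compound 3 `CCOC(=O)CSc1nnc(-c2cc(OC)c(OC)c(OC)c2)n1/N=C/c1ccc(OC)cc1OC` is not yet measured. Its difference from compound 2 is ethoxycarbonyl in place of phenyl on a saturated chain carbon bound to a sulfur; cut one bond further out, the benzylsulfanyl group of compound 2 becomes an ((ethoxycarbonyl)methyl)sulfanyl group.

For the measured compounds named here, no measured step touches this change. Going by the values given here, the only step recorded, a 2.4-fold higher number from compound 1 to compound 2 (0.38 log units; beyond the scatter), alters a substituent on the phenyl ring that here disappears entirely, so it gives no direction for the exchange of the whole ring for an ester. With nothing to go on but the weak numbers of compound 1 and compound 2, the step of a 1.1-fold lower number from compound 2 to compound 3 (0.04 log units; within the scatter) is expected to be small and within the scatter. For compound 3 in this assay a value of 140000 nM is estimated, in the range 45000 nM to 400000 nM.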

Compound 3, half-maximal inhibitory concentration: > 200000 nM
Compound 3 ended at the assay's limit; the forecaster's own chance of this, stated with the estimate: 20%; at least 1.4-fold (0.15 log units) between middle value and limit.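

In this assay compound 3 reads > 200000 nM, which is a limit of the assay and not a number: the limit of > 200000 nM in this assay, at which 1 of the 3 values shown sits.

Replacing the phenyl of the benzylsulfanyl group with ethoxycarbonyl gives an at least 1.3-fold higher number from compound 2 to compound 3 (0.11 log units; that floor lies within the scatter), so this comparison alone establishes no loss, because its floor stays within the scatter. Against the 2-chlorophenyl version of the same position, the ester gives an at least 3.1-fold higher number from compound 1 to compound 3 (0.49 log units; beyond the scatter), which is beyond the scatter, so the ((ethoxycarbonyl)methyl)sulfanyl group does not hold the level of the chloro compound and brings no gain over either aromatic compound.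

Going by these compounds, how far compound 3 lies past its limit remains open, and with it the true size of both steps. The compounds shown also leave open whether a carboxylic acid, an amide or a longer chain on this saturated chain carbon bound to a sulfur would read differently from the ester, and whether a fluoro or methoxy group on the phenyl ring would extend the small gain seen with chloro.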